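Removing the Chloro Substituent on the Way to Compound 4

The source may hold more compounds than are shown below. What is called first, only, known or untested is meant among the compounds shown, and "the series" means these compounds.

Three compounds built on one shared core have been examined in an ADME assay on microsomes from liver (Rattus norvegicus, strain Crj;CD(SD)) for metabolic stability, read by LC-MS, using NADPH, with a stated time of 30 min, tested at 0.1 uM; a lower number here means that less of the compound is left, a higher number that more of the compound is left. Compound 1 `C[C@@]1(c2cc(NC(=O)c3cnc(C(F)F)cn3)ccc2F)C=C(CF)OC(N)=N1` gives 44%, compound 2 `Cc1cc(C#N)cnc1C(=O)Nc1ccc(F)c([C@]2(C)C=C(CF)OC(N)=N2)c1` gives 34%, and compound 3 `C[C@@]1(c2cc(NC(=O)c3ncc(C#N)cc3Cl)ccc2F)C=C(CF)OC(N)=N1` gives 49%. Compound 3 holds the highest of the three numbers; its gap to compound 1 lies within the scatter, whereas the step of a number 15 percentage points higher from compound 2 to compound 3 (beyond the scatter) lies beyond it. Compound 4 `C[C@@]1(c2cc(NC(=O)c3ccc(C#N)cn3)ccc2F)C=C(CF)OC(N)=N1` differs from compound 3 by hydrogen in place of chloro on an aromatic carbon. Among the compounds with values here, no measured step removes a group from that aromatic carbon altogether; the closest guide is a number 15 percentage points higher from compound 2 to compound 3 (beyond the scatter), a modest step beyond the scatter. For compound 4 the step of a number 9 percentage points lower from compound 3 to compound 4 (within the scatter) is therefore expected, a small decrease. Compound 4 is thus estimated to give 40%, within 26% to 54%.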

Compound 4, percent of the compound remaining: 55%
For compound 4 the middle estimate is 15 percentage points below the measured one; the measured number lies above the stated range.
By their numbers in this assay, from the lowest: compounds 2, 1, 3 and 4 (each within the scatter of the next, the first and the last beyond it).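

In this assay the position on the aromatic carbon ortho to a large group turns out not to need a substituent at all: a number 6 percentage points higher from compound 3 to compound 4 (within the scatter) is the step for hydrogen in place of chloro. Hydrogen in place of methyl at that same carbon gives a number 21 percentage points higher from compound 2 to compound 4 (beyond the scatter), so of the three groups seen there only methyl stands apart, and the 5-cyanopyridin-2-yl group also gives a number 11 percentage points higher from compound 1 to compound 4 (beyond the scatter) against 5-(difluoromethyl)pyrazin-2-yl. Nothing available here accounts for these steps. As far as these compounds go, what a methoxy group or an amine on this carbon would give stays open.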